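A few compounds are considered here, and "the series" means these few. Any claim that something is new, unique, unknown or untested is made for them only; others in the source may bear on it.

In a functional assay on A549 cells (Homo sapiens) for cytotoxicity, read by MTT assay, with a stated time of 72 h (a higher number here means a weaker inhibitor, a lower number a stronger inhibitor), compound 1 (`O=C(N/N=C/c1ccc(F)cc1Cl)Nc1cc2c(Nc3ccc(F)c(Cl)c3)ncnc2cc1O[C@H]1CCOC1`) gives 27200 nM and compound 2 (`CCN(CC)c1ccc(/C=N/NC(=O)Nc2cc3c(Nc4ccc(F)c(Cl)c4)ncnc3cc2O[C@H]2CCOC2)c(O)c1`) gives 15700 nM. Compound 3 (`COc1cc2ncnc(Nc3ccc(F)c(Cl)c3)c2cc1NC(=O)N/N=C/c1ccc(C#N)cc1`) gives 32200 nM, within the scatter of compound 1 and beyond the scatter of compound 2, whose number is lower. Compound 4 (`COc1cc2ncnc(Nc3ccc(F)c(Cl)c3)c2cc1NC(=O)N/N=C/c1ccc(OC)c(OC)c1OC`) keeps the core of compound 3 and differs in one place: 2,3,4-trimethoxyphenyl in place of 4-cyanophenyl on a carbon with a double bond to nitrogen. Within the data shown here, the only measured exchange at this place is a 1.7-fold lower number from compound 1 to compound 2 (0.24 log units; within the scatter), made on a different core and with different groups. That single step gives no ground for a shift beyond the scatter in this assay, so none is expected. The estimated step is a 1.2-fold lower number from compound 3 to compound 4 (0.09 log units; within the scatter). For compound 4 the expected value is 26000 nM, with an estimated range of 12000 nM to 55000 nM.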

Compound 4, half-maximal inhibitory concentration: 32800 nM
Compound 4: middle estimate off by 1.3-fold (0.10 log units), on the low side, and the stated range covers the measured number.
By their numbers in this assay, from the lowest: compounds 2, 1, 3 and 4 (each within the scatter of the next, the first and the last beyond it).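

On the core of compound 3, the exchange on the carbon with a double bond to nitrogen gives a 1.0-fold higher number from compound 3 to compound 4 (0.01 log units; within the scatter) in this assay. The entering 2,3,4-trimethoxyphenyl has more heavy atoms and more hydrogen-bond acceptors than 4-cyanophenyl, and neither the larger group nor the loss of the nitrile moves the number beyond the scatter at this place on this core. No measured evidence bears on why the two groups read alike.

Open, from the compounds shown here alone, is whether a carboxylic acid or an aliphatic amine on the ring at this place would give a different number. Also open, going by these compounds, is whether an alkyl chain in place of the ring would do so.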